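The source may report more compounds than this note shows. Statements on the series, on what has been measured and on what is new or still open speak of the compounds shown alone.

Measured so far:
compound 1 `Nc1nc(N)nc(-c2cc(Br)ccc2Br)n1` — 2.09
compound 2 `Nc1nc(N)nc(-c2cccc(C(F)(F)F)c2)n1` — 2.67

In a physicochemical assay for lipophilicity (on this read-out lower numbers stand for lower lipophilicity and higher numbers for higher lipophilicity), compound 2 gives 2.67, the higher of the two numbers. Compound 1 stands lower at 2.09, a gap beyond the scatter.

Compound 3 `Nc1nc(N)nc(-c2cccc(Br)c2)n1` has not been measured. It differs from compound 2 by bromo in place of trifluoromethyl on an aromatic carbon. Among the measured compounds shown here, no measured pair shows this change, so its size is not known from the data. In this assay a step within the scatter is expected, if anything slightly downward.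

For compound 3 the estimate in this assay is 2.55, with a range of 2.2 to 2.9. This amounts to an expected step of a number 0.12 log units lower from compound 2 to compound 3 (within the scatter).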

Compound 3, partition coefficient: 2.44
Compound 3: middle estimate off by 0.11 log units, on the high side; measured number inside the range.
By their numbers in this assay, from the lowest: compound 1; then compounds 3 and 2 (each within the scatter of the next).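

In this assay, bromo in place of trifluoromethyl on an aromatic carbon gives a number 0.23 log units lower from compound 2 to compound 3 (within the scatter) at this position, so the two groups are not told apart here despite their different heavy-atom counts. Hydrogen in place of bromo on an aromatic carbon gives a number 0.35 log units higher from compound 1 to compound 3 (beyond the scatter) and shows that one bromo fewer need not lower the number in this series. No measured evidence accounts for either step.

The compounds shown leave open how an amine or a carboxylic acid on this aromatic carbon would read. They also leave open whether the step seen for hydrogen in place of bromo holds on other cores.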